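The source may report more compounds than this note shows. Statements on the series, on what has been measured and on what is new or still open speak of the compounds shown alone.

Three compounds share the core of compound 1 `CS(=O)(=O)c1ccc(C(=O)NCCC(=O)N2CCCc3ccccc32)cc1[N+](=O)[O-]`. In an assay on isolated protein for inhibition of thyroid hormone receptor alpha (Homo sapiens), read by fluorescence polarization (on this read-out higher numbers stand for weaker inhibition and lower numbers for stronger inhibition), compound 1 gives > 60000 nM, which is a limit of the assay and not a number (the limit of > 60000 nM in this assay, at which 1 of the 3 values shown sits). Compound 2 `CS(=O)(=O)c1ccc(C(=O)NCC(=O)N(Cc2ccccc2)Cc2ccccc2)cc1[N+](=O)[O-]` gives 1700 nM in this assay. Compound 3 `CS(=O)(=O)c1ccc(C(=O)NCC(=O)N2CCCCC2)cc1[N+](=O)[O-]` gives 44000 nM in this assay, the highest of the two numbers shown; its nearest neighbour is compound 2, whose number is lower by a margin beyond the usual scatter. Compound 4 `CC(C)N(C(=O)CNC(=O)c1ccc(S(C)(=O)=O)c([N+](=O)[O-])c1)C(C)C` differs from compound 3 by diisopropylamino in place of piperidin-1-yl on a carbonyl carbon. No measured step of this kind is shown among these compounds, so no shift beyond the scatter is expected in either direction. The step from compound 3 to compound 4 is expected to be a 1.1-fold lower number from compound 3 to compound 4 (0.04 log units; within the scatter). Compound 4 is therefore estimated at 40000 nM, between 12000 nM and 60000 nM.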

Compound 4, half-maximal inhibitory concentration: > 60000 nM
Compound 4 gave a limit, no number; the forecaster's own chance of this, stated with the estimate: 30%; at least 1.5-fold (0.17 log units) between middle value and limit.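

In this assay compound 4 gives > 60000 nM, which is a limit of the assay and not a number. Diisopropylamino, which has no ring, in place of piperidin-1-yl on a carbonyl carbon brings no lower number, with an at least 1.3-fold higher number from compound 3 to compound 4 (0.13 log units; that floor lies within the scatter). Only a floor of this step can be read, and the true size stays unknown: the limit of > 60000 nM in this assay, at which 2 of the 4 values shown sit.

As far as these compounds go, it remains open whether dimethylamino or morpholin-4-yl on this carbonyl carbon would give a readable number. Also open, from the compounds shown here alone, is what a single benzyl group in this place would do.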